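This account rests on a few compounds, and the source may have more. Where it says the series, first, only, none or still open, it means among the compounds named here.

Measured compounds and their numbers in an assay on cells for agonist activity at ecdysone receptor (Bombyx mori), read by a luciferase reporter, with a stated time of 24 h; a higher number here means that more compound is needed for the effect, a lower number that less compound is needed:

- compound 1, `CCc1ccccc1C(=O)N(NC(=O)c1ccccc1)C(C)(C)C`: 589 nM
- compound 2, `CC(C)(C)N(NC(=O)c1cccc(F)c1)C(=O)c1ccccc1Cl`: 69.2 nM

Among the measured compounds shown here, compound 2 gives the lowest number of the two in this assay; compound 1, the only neighbour, gives a higher number, and that gap is beyond the scatter. For the measured compounds named here, no pair of measured compounds differs in a single place, so no measured step is available to lean on.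

Compound 3, `Cc1cccc(C(=O)NN(C(=O)c2ccccc2Cl)C(C)(C)C)c1C`, is the next compound to be measured. It keeps the core of compound 2 and differs in one place:

2,3-dimethylphenyl in place of 3-fluorophenyl on a carbonyl carbon

Going by the values given here, a change of one aromatic ring substituent pattern on a carbonyl carbon, with no change in donors, acceptors or charge, is expected to move the number in this assay by a modest amount, more likely upward than downward, since compound 2 already holds the lowest number seen and only two compounds are known. The expected step of a 2.9-fold higher number from compound 2 to compound 3 (0.46 log units; beyond the scatter) is therefore a small loss, with a wide range around it.

Compound 3 is estimated at 200 nM, with a range from 40 nM to 1000 nM.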

Compound 3, half-maximal effective concentration: 20 nM
Compound 3: the middle estimate sits 10-fold (1.00 log units) above what was measured; the measured number lies below the stated range.
By their numbers in this assay, from the lowest: compound 3; then compound 2; then compound 1.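

Among the compounds shown here, on a carbonyl carbon whose other neighbours are an amide-type nitrogen, 2,3-dimethylphenyl in place of 3-fluorophenyl gives a 3.5-fold lower number from compound 2 to compound 3 (0.54 log units; beyond the scatter) in this assay, the only single-place step so far. This position therefore accepts a ring carrying two methyl groups and no fluorine without any loss in this assay, and the number moves down, beyond the scatter. Both groups count no hydrogen-bond donors, no hydrogen-bond acceptors and no net charge, and no measurement shown bears on why the number falls.

Still open, as far as these compounds go, is whether one methyl group carries the step or both are needed, which 2-methylphenyl and 3-methylphenyl on the same carbonyl carbon would separate, and how a methoxy group, an amine or a carboxylic acid on this ring would compare. Also open, from the compounds shown here alone, is whether the same exchange gives a step of similar size on the core of compound 1, where the other ring carries an ethyl group instead of the chlorine of compound 2 and compound 3.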